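Chloro in Place of Hydrogen on the Phenyl Ring

This account rests on a few compounds, and the source may have more. Where it says the series, first, only, none or still open, it means among the compounds named here.

All three measured compounds were tested in a functional assay on HeLa cells (Homo sapiens) for cytotoxicity, read by CCK-8 assay, with a stated time of 24 h; on this read-out higher numbers stand for weaker inhibition and lower numbers for stronger inhibition:

Compound 1, `C/C(=C\c1cc(-c2ccccc2)cs1)C(N)=O`: 12700 nM
Compound 2, `C/C(=C\c1cccc(-c2ccc(C)cc2)c1)C(N)=O`: 24800 nM
Compound 3, `C/C(=C\c1cc(-c2ccccc2C)cs1)C(N)=O`: 19400 nM

Compound 1 gives the lowest of the three numbers in this assay, yet its gaps to compound 3 and to compound 2 both fall within the usual scatter, so no ordering among the three can be claimed. Compound 2 gives 24800 nM, and that number and the number for compound 1 sit within the scatter of each other.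

Compound 4, `C/C(=C\c1cc(-c2ccc(Cl)cc2)cs1)C(N)=O`, has not yet been measured. It differs from compound 1 by chloro in place of hydrogen on an aromatic carbon. Going by the values given here, the only measured step that bears on a substituent entering this ring is a 1.5-fold higher number from compound 1 to compound 3 (0.18 log units; within the scatter), where a methyl rather than a chloro enters, and that step stayed within the scatter. On that basis the expected step of a 1.2-fold lower number from compound 1 to compound 4 (0.06 log units; within the scatter) is small and of uncertain direction. Compound 4 is therefore estimated at 11000 nM, with a range from 4000 nM to 30000 nM.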

Compound 4, half-maximal inhibitory concentration: > 50000 nM
Compound 4 ended at the assay's limit; the forecaster's own chance of this, stated with the estimate: 10%; at least 4.5-fold (0.65 log units) between middle value and limit.
By their numbers in this assay, from the lowest: compounds 1, 3 and 2 (each within the scatter of the next). At a limit, above all of these: compound 4.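

In this assay, going by these compounds alone, chloro in place of hydrogen on an aromatic carbon, para to a large group, gives an at least 3.9-fold higher number from compound 1 to compound 4 (0.59 log units; beyond the scatter), the first step in this set that lies beyond the scatter. Compound 4 gives > 50000 nM, which is a limit of the assay and not a number: the limit of > 50000 nM in this assay, at which 1 of the 4 values shown sits. A single heavy atom entering the ring of compound 1 is thus enough to move the number beyond the scatter, which the methyl step, a 1.5-fold higher number from compound 1 to compound 3 (0.18 log units; within the scatter), did not do.

The compounds shown leave open whether this step belongs to chloro alone or would follow any group entering at this carbon. Fluoro, an amine or a carboxylic acid at the same carbon would help to separate those two readings.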